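Pyridin-2-yl in place of pyrimidin-4-yl: working notes

The source may report more compounds than this note shows. Statements on the series, on what has been measured and on what is new or still open speak of the compounds shown alone.

Measured in an ADME assay on MT4 cells (Homo sapiens) for cytotoxicity, with a stated time of 5 days; on this read-out lower numbers stand for higher toxicity in this test and higher numbers for lower toxicity in this test
- compound 1 (`CC(C)(C)C#Cc1cc(N(C(=O)[C@H]2CC[C@H](C)CC2)[C@H]2CC[C@H](OC3CCOC3)CC2)c(C(=O)O)s1`) gives 3070 nM
- compound 2 (`CC(C)(C)C#Cc1cc(N(C(=O)[C@H]2CC[C@H](C)CC2)[C@H]2CC[C@H](Oc3ccc(=O)[nH]n3)CC2)c(C(=O)O)s1`) gives 1480 nM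
- compound 3 (`CC(C)(C)C#Cc1cc(N(C(=O)[C@H]2CC[C@H](C)CC2)[C@H]2CC[C@H](Oc3ccncn3)CC2)c(C(=O)O)s1`) gives 599 nM

Compound 3 has the lowest of the three numbers. Compound 4 (`CC(C)(C)C#Cc1cc(N(C(=O)[C@H]2CC[C@H](C)CC2)[C@H]2CC[C@H](Oc3ccccn3)CC2)c(C(=O)O)s1`) carries pyridin-2-yl in place of pyrimidin-4-yl on an oxygen on a saturated carbon. Within the data shown here, no measured step makes this exact exchange. The closest comparison joins two six-membered aromatic rings (a 2.5-fold lower number from compound 2 to compound 3 (0.39 log units; beyond the scatter)) and is modest. The steps away from oxolan-3-yl are also modest (a 2.1-fold lower number from compound 1 to compound 2 (0.32 log units; beyond the scatter) and a 5.1-fold lower number from compound 1 to compound 3 (0.71 log units; beyond the scatter)). A modest step at most is therefore expected in this assay, with no direction settled by the data. Compound 4 is expected at 520 nM (estimated range 220 nM to 1200 nM). The estimate means a small expected step (a 1.2-fold lower number from compound 3 to compound 4 (0.06 log units; within the scatter)).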

Compound 4, half-maximal cytotoxic concentration: 100 nM
Compound 4: the middle estimate sits 5.2-fold (0.72 log units) above what was measured; the whole stated range lies above it.
By their numbers in this assay, from the lowest: compound 4; then compound 3; then compound 2; then compound 1.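

In this assay the exchange of pyrimidin-4-yl for pyridin-2-yl, at an unchanged heavy-atom count, gives a 6.0-fold lower number from compound 3 to compound 4 (0.78 log units; beyond the scatter) and so shows that one ring nitrogen fewer is enough to move the number beyond the scatter. Pyridin-2-yl also brings the first large steps at this position, a 15-fold lower number from compound 2 to compound 4 (1.17 log units; beyond the scatter) and a 31-fold lower number from compound 1 to compound 4 (1.49 log units; beyond the scatter) in the same direction.

On these data alone, whether an amine or a methoxy group on the pyridin-2-yl ring would shift the number further stays open. Nothing available gives a cause for these steps.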